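Intrinsic activity across a phosphoserine ester series

The compounds below may be only part of what the source reports. "The series", "measured", "known", "first", "only" and "open" are said of these compounds alone.

Measured compounds:
compound 1, `N[C@@H](COP(=O)(O)OCCCOC(=O)CCc1ccccc1OCCCCCCOc1ccccc1)C(=O)O`, 0.071
compound 2, `Cc1cccc(Oc2cccc(COc3ccccc3CCC(=O)OCCCOP(=O)(O)OC[C@H](N)C(=O)O)c2)c1`, 0.29
compound 3, `N[C@@H](COP(=O)(O)OCCCOC(=O)CCc1ccccc1OCc1cccc(Oc2ccccc2Cl)c1)C(=O)O`, 0.069

In an assay on cells for activation of probable G-protein coupled receptor 34 (Mus musculus), with a stated time of 1 h (on this read-out lower numbers stand for smaller maximal responses and higher numbers for larger maximal responses), compound 2 gives 0.29, the highest of the three numbers. Compound 1 gives 0.071 and compound 3 gives 0.069, both well below compound 2, and these two cannot be told apart from each other. Among the compounds with values here, the only single-point step among the measured compounds is the one in which a 2-chlorophenyl takes the place of a 3-methylphenyl on an oxygen on an aromatic ring, a number 0.22 lower from compound 2 to compound 3 (beyond the scatter), a modest drop that lies beyond the scatter.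

Compound 4, `N#Cc1ccc(Oc2cccc(COc3ccccc3CCC(=O)OCCCOP(=O)(O)OC[C@H](N)C(=O)O)c2)cc1`, is not yet measured. Compared with compound 2 it shows the following difference: 4-cyanophenyl in place of 3-methylphenyl on an oxygen on an aromatic ring. The same oxygen on an aromatic ring is touched as in the step to compound 3, and that step, a number 0.22 lower from compound 2 to compound 3 (beyond the scatter), shows that exchanging the 3-methylphenyl at this place can cost a good part of the maximal response. Within the data shown here, on that basis a drop of similar size is expected, though with wide uncertainty because only one such step, a number 0.22 lower from compound 2 to compound 3 (beyond the scatter), exists to go by. Compound 4 is therefore estimated at 0.12, with a range from 0.04 to 0.28, which would mean an expected a number 0.17 lower from compound 2 to compound 4 (beyond the scatter).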

Compound 4, intrinsic activity: the largest response reached, as a fraction of the reference agonist's: 0.041
Compound 4: middle estimate off by 0.079, on the high side; low and high end bracket the measured number.
By their numbers in this assay, from the lowest: compounds 4, 3 and 1 (each within the scatter of the next); then compound 2.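

In this assay, a second replacement of the 3-methylphenyl on an oxygen on an aromatic ring also lowers the maximal response (a number 0.25 lower from compound 2 to compound 4 (beyond the scatter)), so the loss seen with the 2-chlorophenyl is no longer a single case at this place. The 4-cyanophenyl and the 2-chlorophenyl, though different groups, cannot be told apart here (a number 0.028 lower from compound 3 to compound 4 (within the scatter)), and of the three groups shown on this oxygen, only the 3-methylphenyl of compound 2 stands clear of the others. Nothing measured alongside these numbers accounts for the drop from either replacement.

On these data alone, it remains open whether the response of compound 2 depends on the methyl group itself or on where that group sits, a question that a 4-methylphenyl and a 3-cyanophenyl at the same place would help to separate. Also open, as far as these compounds go, is how an unsubstituted phenyl, or a phenyl ring carrying an amine or a carboxylic acid, would behave on this oxygen in this assay when compared with the 3-methylphenyl.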